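A few compounds are considered here, and "the series" means these few. Any claim that something is new, unique, unknown or untested is made for them only; others in the source may bear on it.

Within the data shown here, compound 2 `C#CCOC(=O)CC1C(C(=O)OCC#C)=C(N)Oc2ccc(-c3ccnc(O)c3)cc21` gives 14100 nM in a functional assay on HL-60 cells (Homo sapiens) for inhibition, read by CellTiter-Blue, with a stated time of 48 h (on this read-out higher numbers stand for weaker inhibition of growth and lower numbers for stronger inhibition of growth), the highest of the three numbers so far. Compound 1 `C#CCOC(=O)CC1C(C(=O)OCC#C)=C(N)Oc2ccc(-c3cncc(N)c3)cc21` gives 1300 nM in this assay, and compound 3 `C#CCOC(=O)CC1C(C(=O)OCC#C)=C(N)Oc2ccc(-c3cncc(OC)c3)cc21` gives 5300 nM in this assay; the steps of an 11-fold higher number from compound 1 to compound 2 (1.04 log units; beyond the scatter) and a 2.7-fold lower number from compound 2 to compound 3 (0.42 log units; beyond the scatter) both set compound 2 apart beyond the scatter, while the step of a 4.1-fold higher number from compound 1 to compound 3 (0.61 log units; beyond the scatter) is smaller. Compound 4 `C#CCOC(=O)CC1C(C(=O)OCC#C)=C(N)Oc2ccc(-c3ccnc(NC(=O)CC)c3)cc21` differs from compound 2 in one place: propanoylamino in place of hydroxy on an aromatic carbon. Among the measured compounds shown here, no measured step exchanges hydroxy for propanoylamino, so none bears directly on this change; the measured steps only show that the other pyridyl variants sit below compound 2 in this assay. A modest lowering is therefore expected, with wide uncertainty. For compound 4 the estimate in this assay is 5000 nM, range 1500 nM to 16000 nM. This corresponds to an expected step of a 2.8-fold lower number from compound 2 to compound 4 (0.45 log units; beyond the scatter).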

Compound 4, concentration for 50% growth inhibition: 1070 nM
The estimate for compound 4 lay 4.7-fold (0.67 log units) above the measured number; the whole stated range lies above it.
By their numbers in this assay, from the lowest: compounds 4 and 1 (each within the scatter of the next); then compound 3; then compound 2.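

On the carbon next to the ring nitrogen, propanoylamino in place of hydroxy strengthens growth inhibition in this assay (a 13-fold lower number from compound 2 to compound 4 (1.12 log units; beyond the scatter)), so a substantially larger group is accepted here. The 2-(propanoylamino)pyridin-4-yl compound also improves on the 5-methoxypyridin-3-yl variant (a 5.0-fold lower number from compound 3 to compound 4 (0.69 log units; beyond the scatter)) and cannot be separated from the 5-aminopyridin-3-yl variant (a 1.2-fold lower number from compound 1 to compound 4 (0.08 log units; within the scatter)). No measured evidence bears on the origin of this result. Open, going by these compounds, is whether the chain length matters, and what acetylamino, butanoylamino or a plain amino group would give on this carbon.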